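Thiophene to pyridine swap on the shared core

This account rests on a few compounds, and the source may have more. Where it says the series, first, only, none or still open, it means among the compounds named here.

Measured so far in a functional assay for inhibition, with Homo sapiens as the target; a lower number here means a stronger inhibitor, a higher number a weaker inhibitor:
compound 1, `CCN(CC)CCCOc1ccc(Nc2nccc(-c3ccncc3)n2)cc1`, 1300 nM
compound 2, `CC1CCN(c2ccc(Nc3nccc(-c4ccccn4)n3)cc2)CC1`, 1900 nM
compound 3, `CC1CCN(c2ccc(Nc3nccc(-c4cccs4)n3)cc2)CC1`, 400 nM

Compound 3 gives the lowest number of the three in this assay, with compound 1 nearest and compound 2 furthest, both separated from it by more than the scatter. For the measured compounds named here, the one step between compounds differing in a single place is a 4.8-fold lower number from compound 2 to compound 3 (0.68 log units; beyond the scatter), so exchanging a pyridine for the thiophene at that position moved the number down by a modest amount.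

Compound 4, `CC1CCN(c2ccc(Nc3nccc(-c4ccncc4)n3)cc2)CC1`, is not yet measured. It differs from compound 3 in one place: pyridin-4-yl in place of thiophen-2-yl on an aromatic carbon. Going by the values given here, the step from compound 2 to compound 3 is the only direct guide, and it runs the other way: putting a pyridine back at this position is expected to raise the number again. Compound 1, which also carries a pyridin-4-yl at this position but a different group on the aniline ring, gives 1300 nM in this assay, consistent with a number in that region. Compound 4 is therefore estimated at 1300 nM, within 500 nM to 3500 nM, a step of a 3.3-fold higher number from compound 3 to compound 4 (0.51 log units; beyond the scatter) expected from compound 3.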

Compound 4, half-maximal inhibitory concentration: 600 nM
Estimate against measurement, compound 4: 2.2-fold (0.34 log units) above; low and high end bracket the measured number.
By their numbers in this assay, from the lowest: compounds 3 and 4 (each within the scatter of the next); then compounds 1 and 2 (each within the scatter of the next).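

In this assay the step of a 1.5-fold higher number from compound 3 to compound 4 (0.18 log units; within the scatter) stays within the scatter, so at this position, next to the ring nitrogen, pyridin-4-yl and thiophen-2-yl cannot be told apart. The step of a 3.2-fold lower number from compound 2 to compound 4 (0.50 log units; beyond the scatter) shows that the earlier change did not reflect thiophene against pyridine as such, since pyridin-4-yl and pyridin-2-yl are not interchangeable here. For the compounds shown here, with pyridin-4-yl held constant, the step of a 2.2-fold lower number from compound 1 to compound 4 (0.34 log units; beyond the scatter) gives the first direct reading at the other varied place, where 4-methylpiperidin-1-yl replaces 3-(diethylamino)propoxy.

Going by these compounds, it remains open whether pyridin-3-yl or furan-2-yl on the shared core would fall with compound 3 and compound 4 or with compound 2. No measured evidence shown here accounts for these steps.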